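The source may report more compounds than this note shows. Statements on the series, on what has been measured and on what is new or still open speak of the compounds shown alone.

Measured so far:
compound 1 `COc1nc(-c2ccncc2)ccc1[C@@H](c1ccccc1)[C@@](O)(CCN(C)C)c1cccc2ccccc12`: 9.6 ug/mL
compound 2 `COc1ncc(-c2ccccc2)cc1[C@@H](c1ccccc1)[C@@](O)(CCN(C)C)c1cccc(F)c1F`: 28.1 ug/mL
compound 3 `COc1ncc(-c2ccccc2)cc1[C@@H](c1ccccc1)[C@@](O)(CCN(C)C)c1cccc2ccccc12`: 30.4 ug/mL

In a toxicity assay on HeLa cells (Homo sapiens) for cytotoxicity (a lower number here means that less compound is tolerated, a higher number that more compound is tolerated), compound 1 gives the lowest of the three numbers; compound 2 and compound 3 both sit beyond the scatter above it. Compound 4 `COc1nc(-c2ccccc2Cl)ccc1[C@@H](c1ccccc1)[C@@](O)(CCN(C)C)c1cccc2ccccc12` is derived from compound 1 by one change: 2-chlorophenyl in place of pyridin-4-yl on an aromatic carbon. For the measured compounds named here, the only measured step that is a single change is a 1.1-fold higher number from compound 2 to compound 3 (0.03 log units; within the scatter), which concerns a different position, the group on the saturated chain carbon, and stayed within the scatter. Going by the values given here, no measured pair isolates the exchange of the aryl group on the core, so the data give no direct guide for it. Among the compounds with values here, the only hint is that compound 2 and compound 3, which carry a phenyl on the core rather than a pyridin-4-yl, show higher numbers than compound 1. For compound 4 a modest move toward those higher numbers is therefore expected, about a 1.6-fold higher number from compound 1 to compound 4 (0.19 log units; within the scatter), though a number within the scatter of compound 1 would not surprise. The estimate for compound 4 in this assay is 15 ug/mL, with a range from 6 ug/mL to 38 ug/mL.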

Compound 4, half-maximal cytotoxic concentration: > 64 ug/mL
Compound 4: only a limit was reported; the forecaster's own chance of this, stated with the estimate: 5%; at least 4.2-fold (0.63 log units) between middle value and limit.
By their numbers in this assay, from the lowest: compound 1; then compounds 2 and 3 (each within the scatter of the next). At a limit, above all of these: compound 4.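

In this assay, the aryl group on the shared core turns out to matter: 2-chlorophenyl in place of pyridin-4-yl gives an at least 6.6-fold higher number from compound 1 to compound 4 (0.82 log units; beyond the scatter). Compound 4 gives > 64 ug/mL, which is a limit of the assay and not a number. The only earlier single change, at the saturated chain carbon, stayed within the scatter, so this is the first single change shown to move the number beyond it, and the size of the move is known only as a minimum: the limit of > 64 ug/mL in this assay, at which 1 of the 4 values shown sits.

The step removes a ring nitrogen and brings in a chlorine together, and the compounds shown do not tell which of the two matters. Also open, going by these compounds, is what this position would give with an unsubstituted phenyl, or with a phenyl carrying an amine or a carboxylic acid.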